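Swapping a Propyl Chain for Isopropoxy on a Shared Core

A few compounds are considered here, and "the series" means these few. Any claim that something is new, unique, unknown or untested is made for them only; others in the source may bear on it.

Measured compounds:
compound 1, `COc1cc(Cc2nc3c(N)ncnc3n2CC(C)CCCO)cc(OC)c1OC`, 8770000 nM
compound 2, `CCCCCn1c(Cc2cc(OC)c(OC)c(OC)c2)nc2c(N)nc(F)nc21`, 286000000 nM

Both compounds were tested in a functional assay on MCF7 cells (Homo sapiens) for cytotoxicity; on this read-out higher numbers stand for an effect only at larger amounts of compound and lower numbers for an effect already at smaller amounts. Compound 1 gives 8770000 nM and compound 2 gives 286000000 nM. Compound 2 therefore stands as the higher of the two numbers. The gap between compound 2 and compound 1 lies beyond the scatter of repeated measurements, and the two compounds truly differ on this read-out. The two structures differ in more than one place, so no single change can be tied to that gap.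

Compound 3, `COc1cc(Cc2nc3c(N)nc(F)nc3n2CCOC(C)C)cc(OC)c1OC`, has not yet been measured. It differs from compound 2 in one place: isopropoxy in place of propyl on a saturated chain carbon, two bonds along the chain from an aromatic nitrogen. The fluorine and the trimethoxy-substituted ring of compound 2 are kept. Within the data shown here, no measured pair in this set isolates such a change, so there is no direct guide to its size. A step of modest size, not clearly beyond the scatter, is expected, as described by a 1.9-fold lower number from compound 2 to compound 3 (0.28 log units; within the scatter). Compound 3 is expected to give about 150000000 nM, within a range from 20000000 nM to 600000000 nM.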

Compound 3, half-maximal effective concentration: 769000000 nM
Compound 3: the middle estimate sits 5.1-fold (0.71 log units) below what was measured; the measured number lies above the stated range.
By their numbers in this assay, from the lowest: compound 1; then compound 2; then compound 3.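

In this assay, replacing propyl with isopropoxy on a saturated chain carbon, two bonds along the chain from an aromatic nitrogen, gives a 2.7-fold higher number from compound 2 to compound 3 (0.43 log units; beyond the scatter) and so means that an effect appears only at larger amounts of compound. Among these compounds, this is the first step here that isolates a single change at this position, and it shows that the read-out responds to what is attached there, even though the step itself is modest. Nothing measured here explains why the number rises.

This single step cannot separate the contribution of the added oxygen from that of the branched shape of the isopropoxy group, and it cannot show whether the same swap would have a similar effect on the core of compound 1, which has no fluorine. It also leaves open how far the number would move in either direction with a different group at this place, such as an amine, a carboxylic acid or a longer chain.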